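Swapping an aryl amide for a piperidine amide

This account rests on a few compounds, and the source may have more. Where it says the series, first, only, none or still open, it means among the compounds named here.

Of the compounds shown here, three sharing one core have been measured in a functional assay on A549 cells (Homo sapiens) for inhibition, read by MTT assay, with a stated time of 72 h; a lower number here means a stronger inhibitor, a higher number a weaker inhibitor. Compound 1 `O=C(CCC(=O)OCCCCCCSc1ccc([N+](=O)[O-])c2nonc12)Nc1ccccc1F` gives 2440 nM. Compound 2 `O=C(CCC(=O)OCCCCCCSc1ccc([N+](=O)[O-])c2nonc12)Nc1ccccc1Cl` gives 2750 nM, and the step of a 1.1-fold higher number from compound 1 to compound 2 (0.05 log units; within the scatter) shows that the two halogens behave alike. Compound 3 `COc1ccc(NC(=O)CCC(=O)OCCCCCCSc2ccc([N+](=O)[O-])c3nonc23)cc1` gives 6480 nM, the highest of the three numbers; the steps of a 2.7-fold higher number from compound 1 to compound 3 (0.42 log units; beyond the scatter) and a 2.4-fold higher number from compound 2 to compound 3 (0.37 log units; beyond the scatter) place it modestly but clearly behind the other two, so within this small set compound 3 is the weakest inhibitor.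

Compound 4 `O=C(CCC(=O)N1CCCCC1)OCCCCCCSc1ccc([N+](=O)[O-])c2nonc12` has not yet been measured. It differs from compound 3 in one place: piperidin-1-yl in place of (4-methoxyphenyl)amino on a carbonyl carbon. Among the compounds with values here, no measured pair shows a change of this kind, so no step bears on it directly. The nearest guide is that the two steps leading to compound 3, which also alter the group on the amide-type nitrogen, were modest in size. A step of similar modest size is therefore expected for compound 4 in this assay, a 1.1-fold higher number from compound 3 to compound 4 (0.03 log units; within the scatter), with no firm direction. Compound 4 is estimated at 7000 nM, most likely falling between 2500 nM and 20000 nM.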

Compound 4, half-maximal inhibitory concentration: 2510 nM
Beside the measured number, compound 4's estimate is 2.8-fold (0.45 log units) above it; low and high end bracket the measured number.
By their numbers in this assay, from the lowest: compounds 1, 4 and 2 (each within the scatter of the next); then compound 3.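

In this assay, the step of a 2.6-fold lower number from compound 3 to compound 4 (0.41 log units; beyond the scatter) shows that the group on this carbonyl carbon can change the number beyond the scatter, and here piperidin-1-yl gives the lower number of the pair. The steps of a 1.1-fold lower number from compound 2 to compound 4 (0.04 log units; within the scatter) and a 1.0-fold higher number from compound 1 to compound 4 (0.01 log units; within the scatter) show that compound 4 cannot be told apart from the two halogen-bearing aryl amides, even though piperidin-1-yl has no aromatic ring and no amide hydrogen, so neither feature is required at this position for a number of this size among these four compounds, with only compound 3 standing apart. Nothing given here accounts for why compound 3 gives the highest number of the four.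

The compounds shown leave open whether a ring on this nitrogen matters at all, which an open-chain diethylamino group, a smaller pyrrolidin-1-yl or a morpholin-4-yl, with an oxygen in its ring, could test on the same carbonyl carbon. They also leave open whether compound 3 differs from the halogen compounds through its methoxy group or through where that group sits, a question that 2-methoxyphenyl and 4-chlorophenyl amides could separate.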